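The source may hold more compounds than are shown below. What is called first, only, known or untested is meant among the compounds shown, and "the series" means these compounds.

Compound 1 `Cc1ccc(S(=O)(=O)NCc2cn(C[C@H](O)[C@H]3OC(=O)C(OCc4ccccc4)=C3OCc3ccccc3)nn2)cc1` is tested in a functional assay on A549 cells (Homo sapiens) for antiproliferative activity, read by MTT assay, with a stated time of 72 h (on this read-out higher numbers stand for weaker inhibition and lower numbers for stronger inhibition), where compound 1 gives 16800 nM, the lowest of the two numbers shown. Compound 3 `O=C1O[C@H]([C@@H](O)Cn2cc(CNS(=O)(=O)c3ccc(F)cc3)nn2)C(OCc2ccccc2)=C1OCc1ccccc1` gives 22500 nM, and the step of a 1.3-fold higher number from compound 1 to compound 3 (0.13 log units; within the scatter) lies within the scatter. Compound 2 `O=C1O/C(=C\Cn2cc(-c3cc(F)cc(F)c3)nn2)C(OCc2ccccc2)=C1OCc1ccccc1` gives only a limit, > 100000 nM. Compound 4 `COc1ccccc1-c1cn(C[C@H](O)[C@H]2OC(=O)C(OCc3ccccc3)=C2OCc2ccccc2)nn1` differs from compound 1 by 2-methoxyphenyl in place of (((4-methylphenyl)sulfonyl)amino)methyl on an aromatic carbon. Among the measured compounds shown here, no measured step covers a change of this kind; the single measured step swaps one small group on a remote ring and offers no guidance. Compound 2 carries an aromatic ring rather than the sulfonamide arm, but it also differs elsewhere, so its limit of > 100000 nM in this assay, at which 1 of the 3 values shown sits, is only a loose hint. Compound 4 is therefore expected at 30000 nM, in the range 8000 nM to 100000 nM, an estimated step of a 1.8-fold higher number from compound 1 to compound 4 (0.25 log units; within the scatter).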

Compound 4, half-maximal inhibitory concentration: > 100000 nM
Compound 4 gave a limit, no number (the forecaster's own chance of this, stated with the estimate: 25%); at least 3.3-fold (0.52 log units) between middle value and limit.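

Replacing the sulfonamide arm on this aromatic carbon with 2-methoxyphenyl gives an at least 5.9-fold higher number from compound 1 to compound 4 (0.77 log units; beyond the scatter), and likewise an at least 4.4-fold higher number from compound 3 to compound 4 (0.64 log units; beyond the scatter). Compound 4 gives no number, only a limit of the assay: the limit of > 100000 nM in this assay, at which 2 of the 4 values shown sit. Unlike the earlier swap on the remote ring, this change shows that the position is sensitive to what it carries in this assay.

Which part of the arm matters remains open, whether the sulfonyl group, the amino hydrogen or the distant ring. How a simple amine or a longer chain would read on this carbon is also unknown.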